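Growing the Benzyl Substituent and Watching Maximal Response

This account rests on a few compounds, and the source may have more. Where it says the series, first, only, none or still open, it means among the compounds named here.

Compound 1 `O=C(O)CCc1ccc(NCc2ccccc2)cc1` and compound 2 `O=C(O)CCc1ccc(NCc2cccc(C(F)(F)F)c2)cc1` share one core and differ in a single group. In a functional assay on 1321-N1 cells for agonist activity at Free fatty acid receptor 1 (Homo sapiens), read by calcium flux (on this read-out lower numbers stand for smaller maximal responses and higher numbers for larger maximal responses), compound 1 gives 89% and compound 2 gives 102%, so compound 1 stands lowest of the two numbers. That change, trifluoromethyl in place of hydrogen on an aromatic carbon, gave a number 13 percentage points higher from compound 1 to compound 2 (beyond the scatter). Compound 3 `O=C(O)CCc1ccc(NCc2ccc(Oc3ccccc3)cc2)cc1` is not yet measured; it differs from compound 1 by phenoxy in place of hydrogen on an aromatic carbon. Among the measured compounds shown here, only that one step bears on this change, and it was modest, so a modest rise in this assay is expected. Compound 3 is expected to give 98%, between 84% and 112%. This amounts to an expected a number 9 percentage points higher from compound 1 to compound 3 (within the scatter).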

Compound 3, largest response reached (reported as efficacy), in percent of the reference or control that the assay uses: 100%
Compound 3: middle estimate off by 2 percentage points, on the low side; the measured number falls inside the stated range.
By their numbers in this assay, from the lowest: compound 1; then compounds 3 and 2 (each within the scatter of the next).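

Phenoxy adds 7 heavy atoms, including a six-membered aromatic ring of carbon only, on an aromatic carbon para to a large group. Even so, this assay gives a number 11 percentage points higher from compound 1 to compound 3 (beyond the scatter), so adding a group of this size at this place does not lower the maximal response. No measurement here explains the rise.

On these data alone, it remains open whether a smaller group such as methoxy on the same carbon would also raise the response. The same question applies to benzyloxy, which holds the added ring on a longer link.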